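A few compounds are considered here, and "the series" means these few. Any claim that something is new, unique, unknown or untested is made for them only; others in the source may bear on it.

Compound 1 `CC(C)CCOc1cc(C(F)(F)F)ccc1CNC(=O)C(C)c1ccc(NS(C)(=O)=O)c(F)c1` gives 0.5 nM in an assay on CHO cells for antagonist activity at transient receptor potential cation channel subfamily V member 1 (Homo sapiens), read by FLIPR; on this read-out higher numbers stand for weaker inhibition and lower numbers for stronger inhibition. Compound 2 `CC(C(=O)NCc1ccc(C(F)(F)F)cc1SC1CCCC1)c1ccc(NS(C)(=O)=O)c(F)c1` gives 0.3 nM in this assay, the lowest of the two numbers recorded so far, yet the step of a 1.7-fold lower number from compound 1 to compound 2 (0.22 log units; within the scatter) lies within the scatter, so the two compounds cannot be separated on this read-out. Compound 3 `CC(C(=O)NCc1ccc(C(F)(F)F)cc1-c1cccc(F)c1)c1ccc(NS(C)(=O)=O)c(F)c1` has not yet been measured. It differs from compound 2 in one place: 3-fluorophenyl in place of cyclopentylsulfanyl on an aromatic carbon. Within the data shown here, the only measured step, a 1.7-fold lower number from compound 1 to compound 2 (0.22 log units; within the scatter), also exchanged the group on this aromatic carbon and moved the number little; how a 3-fluorophenyl compares with the cyclopentylsulfanyl it replaces cannot be read from the two compounds in hand. By this precedent the expected step is a 2.0-fold higher number from compound 2 to compound 3 (0.30 log units; within the scatter), within the scatter. Compound 3 is therefore estimated at 0.6 nM, within a range from 0.15 nM to 3 nM.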

Compound 3, inhibition constant: 1.9 nM
For compound 3 the middle estimate is 3.2-fold (0.50 log units) below the measured one; the measured number falls inside the stated range.
By their numbers in this assay, from the lowest: compounds 2 and 1 (each within the scatter of the next); then compound 3.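

In this assay this aromatic carbon proves not indifferent to the group it carries: 3-fluorophenyl brings a 6.3-fold higher number from compound 2 to compound 3 (0.80 log units; beyond the scatter) and a 3.8-fold higher number from compound 1 to compound 3 (0.58 log units; beyond the scatter) and both steps lie beyond the scatter, unlike the earlier exchange of isopentyloxy for cyclopentylsulfanyl. Among these three compounds, the two with non-aromatic groups stay together, while the one with an aromatic ring stands apart, though that ring is seen in compound 3 alone. No measurement shown accounts for the higher number.

As far as these compounds go, it remains open whether the shift belongs to the aromatic ring or to its fluorine, which an unsubstituted phenyl or a cyclohexyl group would help to separate. Also open, from the compounds shown here alone, is how a pyridine ring, an amine or a methoxy group would compare on this carbon.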